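A Pyridine Exchange in Compound 3

A few compounds are considered here, and "the series" means these few. Any claim that something is new, unique, unknown or untested is made for them only; others in the source may bear on it.

Compound 1 `Oc1c(CN2CCCC2)ccc2cccnc12`: 4640 nM; 4570 nM (2 entries)
Compound 2 `Oc1c(C(c2cccnc2)N2CCCC2)ccc2cccnc12`: 40700 nM

Going by the values given here, in a functional assay on MES-SA cells (Homo sapiens) for inhibition, with a stated time of 72 h (a higher number here means a weaker inhibitor, a lower number a stronger inhibitor), compound 2 gives 40700 nM, the only number available for it, and a further entry for it carries no single value. Compound 1 reads 4640 nM; 4570 nM (2 entries), a lower number, which makes compound 2 the weaker inhibitor of the pair.

Compound 3 `Oc1c(C(c2ccncc2)N2CCCC2)ccc2cccnc12` has not yet been measured. It differs from compound 2 by pyridin-4-yl in place of pyridin-3-yl on a saturated chain carbon bound to an amine nitrogen in a ring and an aromatic carbon, with pyridin-4-yl in place of pyridin-3-yl on a saturated chain carbon bound to an amine nitrogen in a ring and an aromatic carbon. Among the compounds with values here, no measured pair shows this exchange, so the expectation in this assay is anchored on compound 2 at 40700 nM, and no shift beyond the scatter is expected. The expected change is a 1.4-fold lower number from compound 2 to compound 3 (0.13 log units; within the scatter). Compound 3 is estimated at 30000 nM, with an expected range of 10000 nM to 80000 nM.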

Compound 3, half-maximal inhibitory concentration: 5890 nM
The estimate for compound 3 lay 5.1-fold (0.71 log units) above the measured number; measured number outside the range, below it.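

In this assay, the group on the saturated chain carbon bound to an amine nitrogen in a ring and an aromatic carbon proves sensitive to more than the presence of a pyridine ring: pyridin-4-yl in place of pyridin-3-yl gives a 6.9-fold lower number from compound 2 to compound 3 (0.84 log units; beyond the scatter). The two groups match in atoms and in the counts of donors and acceptors, so the pair isolates how the same atoms are joined. The step stands well clear of the agreement between repeat readings in this assay: the several entries of compound 1 in this assay, 4640 nM; 4570 nM (2 entries)

As far as these compounds go, whether pyridin-2-yl or a plain phenyl ring on this carbon would read like compound 2 or like compound 3 remains open. The compounds shown offer this exchange in a single pair and give no reason for the step, so it is unknown whether it would hold on another core.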